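The source may report more compounds than this note shows. Statements on the series, on what has been measured and on what is new or still open speak of the compounds shown alone.

Working notes on the series. Compound 1 `COc1cc(C)cc(-c2c(-c3ccnc(-c4ccc(C(C)=O)cc4)c3)cnn2CC#N)c1` is measured in a functional assay on LOX IMVI cells (Homo sapiens) for cytotoxicity, read by sulforhodamine B assay, with a stated time of 48 h, tested at 10 uM (a higher number here means a weaker effect of the compound at the concentration tested, a lower number a stronger effect), and gives 21%, the highest of the two numbers in hand. The other measured compound is compound 2 `COc1cc(C)cc(-c2nn(CC#N)cc2-c2ccnc(-c3ccc(N(C)C)cc3)c2)c1`, which in this assay gives -23%, a number well beyond the scatter away from compound 1. Going by the values given here, no step between two measured compounds that differ in one place is available, so these two values can only be read side by side.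

Compound 3 `COc1cc(C)cc(-c2c(-c3ccnc(-c4ccc(N(C)C)cc4)c3)cnn2CC#N)c1` is not yet measured in this assay. It differs from compound 1 in one place: dimethylamino in place of acetyl on an aromatic carbon. The same dimethylamino group is also carried by compound 2, whose value -23% sits far under that of compound 1. On that basis a downward step is expected, beyond the scatter, from compound 1 to compound 3: a number 31 percentage points lower from compound 1 to compound 3 (beyond the scatter). For compound 3 the estimate in this assay is -10%, with a range from -40% to 25%.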

Compound 3, a percentage reported as activity, at one concentration (the size of the read-out at that concentration, not a potency): 10%
Compound 3: the middle estimate sits 20 percentage points below what was measured, within the range that was stated.
By their numbers in this assay, from the lowest: compound 2; then compound 3; then compound 1.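

In this assay, going by these compounds alone, the first direct reading at this position comes from replacing 4-acetylphenyl with 4-(dimethylamino)phenyl, which gives a number 11 percentage points lower from compound 1 to compound 3 (beyond the scatter) and so a modest shift towards a stronger effect. Within the data shown here, this step isolates the change to one group on an aromatic carbon para to a large group, with the same count of heavy atoms leaving and entering, something the side-by-side reading of the earlier compounds could not do. Among these compounds, compound 3 gives 10% in this assay, so the single change has a real but limited effect on the read-out.

Among the compounds shown here, with only this one step, it remains open how a primary amine, a carboxylic acid or a longer chain at the same place would compare with acetyl and dimethylamino. As far as these compounds go, it is also open whether the same change would move the number in the same direction on the core of compound 2. Nothing available bears on why this change moves the read-out.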